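Dropping the chloro from a cinnamoyl hydrazone

The compounds below may be only part of what the source reports. "The series", "measured", "known", "first", "only" and "open" are said of these compounds alone.

Measured compounds:
Compound 1, `COc1ccc(OC)c(/C=C/c2nnc(Nc3ccc(Cl)cc3)o2)c1` — in a functional assay on OVCAR-4 cells (Homo sapiens) for antiproliferative activity, read by sulforhodamine B assay, with a stated time of 48 h (a lower number here means a stronger inhibitor of growth, a higher number a weaker inhibitor of growth), compound 1 gives 2440 nM.
Compound 2, `COc1ccc(OC)c(/C=C/C(=O)N/N=C/c2ccc(Cl)cc2)c1` — in this assay compound 2 gives 439 nM.

Compound 2 holds the lower of the two numbers seen in this assay. Compound 1 sits a good way higher, and the gap between them is beyond the usual scatter of repeated measurements; the two share the dimethoxyphenyl vinyl portion and the chlorophenyl end, but differ in the linker that joins them, so their two values only show that the acylhydrazone arrangement of compound 2 reads as the stronger growth inhibitor of the pair.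

Compound 3, `COc1ccc(OC)c(/C=C/C(=O)N/N=C/c2ccccc2)c1`, keeps the whole acylhydrazone linker of compound 2 and changes only the far ring: hydrogen in place of chloro on an aromatic carbon. For the measured compounds named here, no pair of measured compounds differs in exactly this way, so the size of this step has to be anticipated rather than read off. With only a chlorine removed from a position para to a large group, a modest weakening is expected, of a size that may not clear the scatter, which is what the estimated step of a 1.8-fold higher number from compound 2 to compound 3 (0.26 log units; within the scatter) expresses. Compound 3 is therefore estimated at 800 nM, with a plausible range from 300 nM to 2500 nM.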

Compound 3, concentration for 50% growth inhibition: 14300 nM
Beside the measured number, compound 3's estimate is 18-fold (1.25 log units) below it, and the stated range ends below it.
By their numbers in this assay, from the lowest: compound 2; then compound 1; then compound 3.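

In this assay, the change from 4-chlorophenyl to phenyl, with the acylhydrazone linker and the dimethoxyphenyl vinyl portion left untouched, gives a 33-fold higher number from compound 2 to compound 3 (1.51 log units; beyond the scatter) and so shows that this single atom on the far ring carries much of the growth inhibition seen with this linker. Compound 1 could not show this, as it carries the same chlorophenyl end and differs from compound 2 only in the linker, so the earlier comparison said nothing about the chloro itself. Nothing at hand bears on why removing the chloro from this place, para to a large group, costs so much.

The compounds shown do not tell whether chlorine itself is needed here or whether another group on the same aromatic carbon, such as fluoro, bromo, methyl or methoxy, would hold the growth inhibition of compound 2. They also leave open whether the chloro matters as much with the linker of compound 1, since no phenyl partner of that compound stands among them.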